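Sulfonylpiperidine series: hydroxypiperidinyl in place of tolyl

The source may hold more compounds than are shown below. What is called first, only, known or untested is meant among the compounds shown, and "the series" means these compounds.

For the measured compounds named here, compound 1 `COc1ccccc1-c1cccc(S(=O)(=O)N2CCC(N3CCC(C)CC3)CC2)c1` and compound 2 `Cc1ccc(C2CCN(S(=O)(=O)c3c(C)cc(C)cc3C)CC2)cc1` are the two measured members. In a functional assay on DLD-1 cells (Homo sapiens) for antiproliferative activity, read by CellTiter-Glo, with a stated time of 72 h (a lower number here means a stronger inhibitor, a higher number a weaker inhibitor), compound 1 gives 21 nM, and compound 2 gives 2200 nM, the highest of the two numbers, with the gap to compound 1 lying beyond the scatter. Compound 3 `Cc1cc(C)c(S(=O)(=O)N2CCC(N3CCC(O)CC3)CC2)c(C)c1` has not been measured; it differs from compound 2 by 4-hydroxypiperidin-1-yl in place of 4-methylphenyl on a saturated ring carbon. Going by the values given here, no single-change step between measured compounds is available, so the expected step is read from compound 1 giving 21 nM on a related saturated ring. A step beyond the scatter toward lower numbers is expected, a 7.3-fold lower number from compound 2 to compound 3 (0.87 log units; beyond the scatter). Compound 3 is estimated at 300 nM, within 60 nM to 1500 nM.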

Compound 3, half-maximal inhibitory concentration: 106 nM
Beside the measured number, compound 3's estimate is 2.8-fold (0.45 log units) above it; the range from low to high includes it.
By their numbers in this assay, from the lowest: compound 1; then compound 3; then compound 2.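

In this assay, for the compounds shown here, 4-hydroxypiperidin-1-yl in place of 4-methylphenyl on a saturated ring carbon gives a 21-fold lower number from compound 2 to compound 3 (1.32 log units; beyond the scatter), the first single-change step. The read-out is therefore sensitive to the group at this position, and an aromatic carbon ring is not needed there at equal heavy-atom count. Nothing available accounts for the size of the step. Going by these compounds, whether the hydroxyl or the ring nitrogen carries the gain stays open. Plain piperidin-1-yl, 4-methoxypiperidin-1-yl or 4-aminopiperidin-1-yl at this position would separate these contributions.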